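The compounds below may be only part of what the source reports. "The series", "measured", "known", "first", "only" and "open" are said of these compounds alone.

In a functional assay on HeLa cells (Homo sapiens) for cytotoxicity, read by MTT assay, with stated times of 1 h, 15 min and 48 h (a lower number here means a stronger inhibitor, a higher number a weaker inhibitor), compound 1 `N#C/C(=C\c1ccc(-c2ccc(-c3ccc(N(c4ccccc4)c4ccccc4)cc3)s2)s1)C(=O)O` gives 210 nM. Compound 2 `COC(=O)/C(C#N)=C/c1ccc(-c2ccc(-c3ccc(N(c4ccccc4)c4ccccc4)cc3)s2)s1` gives > 100000 nM, which is a limit of the assay and not a number. Among the compounds with values here, the one measured step here is an at least 470-fold higher number from compound 1 to compound 2 (2.67 log units; beyond the scatter), and it comes with methyl in place of hydrogen on an oxygen next to a carbonyl group. Compound 3 `CC(C)(C)OC(=O)/C(C#N)=C/c1ccc(-c2ccc(-c3ccc(N(c4ccccc4)c4ccccc4)cc3)s2)s1` changes that same place again, with tert-butyl in place of methyl on an oxygen next to a carbonyl group. Like compound 2, it lacks the hydrogen of compound 1. Within the data shown here, no measured pair compares methyl with tert-butyl, so this expectation rests on one large step alone, an at least 470-fold higher number from compound 1 to compound 2 (2.67 log units; beyond the scatter). No recovery towards compound 1 is expected. The step expected in this assay is a number no higher from compound 2 to compound 3 (the limit leaves the size open), with no clear direction foreseen. For compound 3 the estimate is 100000 nM, with an expected range from 40000 nM to 200000 nM.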

Compound 3, half-maximal inhibitory concentration: > 100000 nM
Compound 3 ended at the assay's limit (the forecaster's own chance of this, stated with the estimate: 80%); the middle value lies on the limit itself.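

In this assay, tert-butyl on this oxygen goes with an at least 470-fold higher number from compound 1 to compound 3 (2.67 log units; beyond the scatter), so the large change seen with methyl is not confined to that one group. Of the three compounds, only compound 1, which keeps the hydrogen on that oxygen, gives a readable number. The step between methyl and tert-butyl cannot be read, because compound 2 and compound 3 each stand at a limit of the assay and not at a number: the limit of > 100000 nM in this assay, at which 2 of the 3 values shown sit.

The compounds shown leave open whether the hydrogen itself matters or any small group on this oxygen would give the same result. Going by these compounds, a primary amide in place of the carboxylic acid of compound 1 would test this, and it remains unknown how far such a change would move the number.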